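Replacing 2,4-difluorophenyl with pyridin-2-yl on the shared core

The source may report more compounds than this note shows. Statements on the series, on what has been measured and on what is new or still open speak of the compounds shown alone.

Measured values in a functional assay on MIA PaCa-2 cells (Homo sapiens) for cytotoxicity, read by MTT assay, with a stated time of 4 h (a lower number here means a stronger inhibitor, a higher number a weaker inhibitor), are these:
- compound 1 `COC1=CC(=O)c2c(COc3ccc(C#N)cc3)c(C)n(C)c2C1=O` gives 463 nM
- compound 2 `COC1=CC(=O)c2c(COc3ccc(F)cc3)c(C)n(C)c2C1=O` gives 905 nM
- compound 3 `COC1=CC(=O)c2c(COc3ccc(F)cc3F)c(C)n(C)c2C1=O` gives 255 nM

Compound 3 cannot be told apart from compound 1, given a 1.8-fold lower number from compound 1 to compound 3 (0.26 log units; within the scatter), but it stands clear of compound 2, given a 3.5-fold lower number from compound 2 to compound 3 (0.55 log units; beyond the scatter). Compound 4 `COC1=CC(=O)c2c(COc3ccccn3)c(C)n(C)c2C1=O` has pyridin-2-yl in place of 2,4-difluorophenyl on an oxygen on a saturated carbon. Going by the values given here, no measured step makes this exchange. The closest guide is the fluoro in place of hydrogen in a 3.5-fold lower number from compound 2 to compound 3 (0.55 log units; beyond the scatter), and compound 4 carries no fluoro, so a modest rise of similar size is expected. For compound 4 the expected step in this assay is a 3.1-fold higher number from compound 3 to compound 4 (0.50 log units; beyond the scatter). Compound 4 is estimated at 800 nM, with a range from 300 nM to 2200 nM.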

Compound 4, half-maximal inhibitory concentration: 9580 nM
For compound 4 the middle estimate is 12-fold (1.08 log units) below the measured one, outside the stated range (above it).
By their numbers in this assay, from the lowest: compounds 3, 1 and 2 (each within the scatter of the next, the first and the last beyond it); then compound 4.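

In this assay, going by these compounds alone, the earlier compounds varied only the substituents on a carbon-only aromatic ring on this oxygen, whereas pyridin-2-yl brings a large loss against each of them (a 38-fold higher number from compound 3 to compound 4 (1.57 log units; beyond the scatter)) (an 11-fold higher number from compound 2 to compound 4 (1.02 log units; beyond the scatter)) (a 21-fold higher number from compound 1 to compound 4 (1.32 log units; beyond the scatter)). This position is therefore far less tolerant of this ring exchange than the earlier substituent changes suggested. No measurement offered here accounts for the loss.

Because compound 4 also lacks a fluoro or nitrile substituent, the ring nitrogen and the missing substituent cannot be separated. An unsubstituted phenyl ring and a fluoro-bearing pyridine ring would be needed to tell them apart.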